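The source may report more compounds than this note shows. Statements on the series, on what has been measured and on what is new or still open speak of the compounds shown alone.

Three analogues of one shared core have been tested in a functional assay on HeLa cells (Homo sapiens) for antiproliferative activity, read by CCK-8 assay, with a stated time of 48 h; a lower number here means a stronger inhibitor, a higher number a weaker inhibitor. Compound 1, `Cc1ccccc1CSc1n[nH]c(-n2[se]c3ccccc3c2=O)n1`, gives 6130 nM; compound 2, `CCCCCCSc1n[nH]c(-n2[se]c3ccccc3c2=O)n1`, gives 35900 nM; and compound 3, `CCCCCSc1n[nH]c(-n2[se]c3ccccc3c2=O)n1`, gives 30300 nM. Compound 3 thus stands second highest of the three numbers: its nearest neighbour is compound 2, and the change a 1.2-fold lower number from compound 2 to compound 3 (0.07 log units; within the scatter) lies within the scatter, while the change a 4.9-fold higher number from compound 1 to compound 3 (0.69 log units; beyond the scatter) places compound 1 clearly lower.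

Compound 4, `CCCSc1n[nH]c(-n2[se]c3ccccc3c2=O)n1`, differs from compound 3 by hydrogen in place of ethyl on a saturated chain carbon, three bonds along the chain from a sulfur. Among the measured compounds shown here, the only measured step that bears on a shortened chain of this sort is a 1.2-fold lower number from compound 2 to compound 3 (0.07 log units; within the scatter), which was within the scatter, whereas the larger steps of a 5.9-fold higher number from compound 1 to compound 2 (0.77 log units; beyond the scatter) and a 4.9-fold higher number from compound 1 to compound 3 (0.69 log units; beyond the scatter) concern the swap of an aryl group for an alkyl chain and are not of the same kind. Because the step of a 1.2-fold lower number from compound 2 to compound 3 (0.07 log units; within the scatter) was so small, the further shortening in compound 4 is expected to bring no step beyond the scatter, and the estimated step is a 1.1-fold lower number from compound 3 to compound 4 (0.03 log units; within the scatter). Compound 4 is therefore estimated at 28000 nM, with a range from 12000 nM to 70000 nM.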

Compound 4, half-maximal inhibitory concentration: 30400 nM
Compound 4: the middle estimate sits 1.1-fold (0.04 log units) below what was measured; the measured number falls inside the stated range.
By their numbers in this assay, from the lowest: compound 1; then compounds 3, 4 and 2 (each within the scatter of the next).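

In this assay, taking ethyl away in favour of hydrogen on a saturated chain carbon, three bonds along the chain from a sulfur, produces a 1.0-fold higher number from compound 3 to compound 4 (0.00 log units; within the scatter), and the wider change of hydrogen in place of propyl at that place gives a 1.2-fold lower number from compound 2 to compound 4 (0.07 log units; within the scatter), so both lie within the scatter. Where the earlier compounds showed only a small trim of the chain, compounds 2, 3 and 4 now show that a larger cut also leaves the number indistinguishable, and shortening the chain to this extent does not close the gap to the 2-methylphenyl group of compound 1, as a 5.0-fold higher number from compound 1 to compound 4 (0.70 log units; beyond the scatter) lies beyond the scatter. Nothing available explains why these alkyl chains read alike in this assay.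

The compounds shown leave open whether a methyl on the sulfur, a longer chain, or a chain ending in an amine or a carboxylic acid would stay level with compounds 2, 3 and 4. They also leave open whether the difference seen with compound 1 belongs to its phenyl ring or to the methyl on that ring, which a plain benzyl group on the sulfur would separate.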